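Swapping the chloro-aryl hydrazone arm in compound 1

The source may hold more compounds than are shown below. What is called first, only, known or untested is meant among the compounds shown, and "the series" means these compounds.

Measured compounds:
compound 1 `CCCSc1nc(N/N=C/c2ccccc2Cl)c2nnn(Cc3ccccc3)c2n1` gives 10900 nM
compound 2 `CCCSc1nc(N/N=C/c2c[nH]c3ccccc23)c2nnn(Cc3ccccc3)c2n1` gives 7410 nM
compound 3 `C#CCSc1nc(N/N=C/c2ccc(N(C)C)cc2)c2nnn(Cc3ccccc3)c2n1` gives 7620 nM

These three compounds were tested in a functional assay on MGC-803 cells (Homo sapiens) for antiproliferative activity, read by MTT assay, with a stated time of 72 h; a higher number here means a weaker inhibitor, a lower number a stronger inhibitor. Compound 1 gives the highest number of the three, but its gaps to compound 2 and compound 3 are within the scatter, so no ordering can be claimed. For the measured compounds named here, the one step between singly different compounds, a 1.5-fold lower number from compound 1 to compound 2 (0.17 log units; within the scatter), changes the aryl group on the hydrazone carbon and stays within the scatter. Compound 4 `CCCSc1nc(N/N=C(\C)c2ccccc2O)c2nnn(Cc3ccccc3)c2n1` differs from compound 1 by a group of 10 heavy atoms (8 carbon, 1 nitrogen, 1 oxygen; one six-membered aromatic ring of carbon only) in place of a group of 9 heavy atoms (7 carbon, 1 nitrogen, 1 chlorine; one six-membered aromatic ring of carbon only), on a nitrogen on an aromatic ring. Going by the values given here, no measured step covers this exact change, so no shift beyond the scatter is expected, and compound 4 is estimated near compound 1, giving a 1.2-fold lower number from compound 1 to compound 4 (0.08 log units; within the scatter). The expected value for compound 4 is 9000 nM, with a likely range from 4000 nM to 20000 nM.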

Compound 4, half-maximal inhibitory concentration: 2310 nM
Compound 4: the middle estimate sits 3.9-fold (0.59 log units) above what was measured; measured number below the stated range.
By their numbers in this assay, from the lowest: compound 4; then compounds 2, 3 and 1 (each within the scatter of the next).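

In this assay, for the compounds shown here, the new arm gives a 4.7-fold lower number from compound 1 to compound 4 (0.67 log units; beyond the scatter) and so provides the first step beyond the scatter, showing that a change at this place on the shared core can move the number. The entering group differs from the leaving one in several ways at once, with oxygen instead of chlorine and one more carbon, so the step cannot be credited to any single feature. No measurement here explains the step. Still open, from the compounds shown here alone, is which of those differences carries the step, and how an amine or a carboxylic acid on the same ring would read.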